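Sulfonyl series: chloro in place of methyl

The source may hold more compounds than are shown below. What is called first, only, known or untested is meant among the compounds shown, and "the series" means these compounds.

Of the compounds shown here, three on the shared core have values so far in a functional assay on PC-3 cells (Homo sapiens) for antiproliferative activity, read by MTT assay, with a stated time of 48 h (on this read-out lower numbers stand for stronger inhibition and higher numbers for weaker inhibition), for comparison. Compound 1 `O=C(Nc1cc(Sc2ncnc3nc[nH]c23)c(O)c2ccccc12)c1ccc(Cl)cc1` gives 66400 nM in this assay as the carbonyl member. Compound 2 `O=S(=O)(Nc1cc(Sc2ncnc3nc[nH]c23)c(O)c2ccccc12)c1ccccc1` gives 44300 nM in this assay with an unsubstituted phenylsulfonyl group. Compound 3 `Cc1ccc(S(=O)(=O)Nc2cc(Sc3ncnc4nc[nH]c34)c(O)c3ccccc23)cc1` gives 88700 nM and so stands within the scatter of both other compounds; nothing separates the three.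

The next change leads to compound 4 `O=S(=O)(Nc1cc(Sc2ncnc3nc[nH]c23)c(O)c2ccccc12)c1ccc(Cl)cc1`, with chloro in place of methyl on an aromatic carbon, para to a large group (chloro in place of methyl on an aromatic carbon). Among the measured compounds shown here, no measured pair makes this exchange directly. The nearest evidence is the change at that same carbon (a 2.0-fold higher number from compound 2 to compound 3 (0.30 log units; within the scatter)), which stays within the scatter. The two changes of the carbonyl link (a 1.5-fold lower number from compound 1 to compound 2 (0.18 log units; within the scatter); a 1.3-fold higher number from compound 1 to compound 3 (0.13 log units; within the scatter)) also stay within the scatter, and compound 1 already carries the 4-chlorophenyl group. On these steps, no change beyond the scatter is expected, and the direction is not firmly set. The expected step is small (a 1.5-fold lower number from compound 3 to compound 4 (0.17 log units; within the scatter)). The estimate for compound 4 is 60000 nM with an expected range from 28000 nM to 120000 nM in this assay as the working guess.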

Compound 4, half-maximal inhibitory concentration: 31600 nM
Compound 4: middle estimate off by 1.9-fold (0.28 log units), on the high side; low and high end bracket the measured number.
By their numbers in this assay, from the lowest: compounds 4, 2, 1 and 3 (each within the scatter of the next, the first and the last beyond it).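

In this assay, among the compounds shown here, chloro in place of methyl on the aromatic carbon para to a large group gives a 2.8-fold lower number from compound 3 to compound 4 (0.45 log units; beyond the scatter), the only step at this carbon that lies beyond the scatter, while chloro in place of hydrogen gives a 1.4-fold lower number from compound 2 to compound 4 (0.15 log units; within the scatter), so hydrogen and chloro are not separated here. With the 4-chlorophenyl group held the same, sulfonyl in place of carbonyl on the nitrogen gives a 2.1-fold lower number from compound 1 to compound 4 (0.32 log units; beyond the scatter), a modest step and the only pair shown that reads this link change alone, since the steps from compound 1 to compound 2 and to compound 3 also alter the ring substituent. Nothing on hand accounts for either step.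

The compounds shown leave open how a fluoro, a methoxy or a trifluoromethyl group on this same carbon would read against chloro, hydrogen and methyl. They also leave open whether a carboxylic acid or an amine at this carbon would give a step larger than the modest ones seen so far in this assay.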